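The compounds below may be only part of what the source reports. "The series", "measured", "known", "first", "only" and "open" are said of these compounds alone.

Compound 1 `Cc1cc(COc2ccc(F)cc2F)nc(-c2ccccn2)n1` and compound 3 `Cc1cc(COc2c(F)cc(F)cc2F)nc(-c2ccccn2)n1` share a core; the difference between them is fluoro in place of hydrogen on an aromatic carbon. In a physicochemical assay for lipophilicity, at pH 7.4 (a lower number here means a more polar compound, a higher number a more lipophilic compound), compound 1 gives 3.1, and compound 3 gives 3.2, so that the step of a number 0.10 log units higher from compound 1 to compound 3 (within the scatter). Compound 2 `Cc1cc(COc2ccc(F)c(F)c2)nc(-c2ccccn2)n1` has the same atoms as compound 1 joined differently; how its core differs from that of compound 1 is not broken down here. In this assay compound 2 gives 3.2. Compound 4 `Cc1cc(COc2cc(F)c(F)c(F)c2)nc(-c2ccccn2)n1` is yet to be measured; it differs from compound 2 by fluoro in place of hydrogen on an aromatic carbon. This is the same kind of change as from compound 1 to compound 3, though not the same: there the entering fluoro was ortho to a large group and meta to two fluoro groups, here it is ortho to a fluoro group, meta to a fluoro group and meta to a large group. Resting on the step of a number 0.10 log units higher from compound 1 to compound 3 (within the scatter), the expected step is a number 0.15 log units higher from compound 2 to compound 4 (within the scatter). Compound 4 is thus estimated at 3.35, between 3.1 and 3.6.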

Compound 4, distribution coefficient: 3.4
For compound 4 the middle estimate is 0.05 log units below the measured one; the measured number falls inside the stated range.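

In this assay the change of fluoro in place of hydrogen on an aromatic carbon gives a number 0.20 log units higher from compound 2 to compound 4 (within the scatter), and on the other core it gives a number 0.10 log units higher from compound 1 to compound 3 (within the scatter). Both steps lie within the scatter, so this single pair shows that the change made no step beyond the scatter on either core, but it does not show a real shift on either core or a rule that holds for other cores, and the entering fluoro stands in a different place in each pair. Nothing given here bears on why the steps have these sizes.

As far as these compounds go, what remains open is how this assay would respond to a different group at these places, such as an amine or a carboxylic acid. The compounds shown also leave open whether a longer chain in place of the methyl group would alter the step.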